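Aryl variation on the anilino nitrogen of the shared core

A few compounds are considered here, and "the series" means these few. Any claim that something is new, unique, unknown or untested is made for them only; others in the source may bear on it.

Measured compounds:
compound 1 `COc1ccc(Nc2ncc(C(F)(F)F)c(N3Cc4cccc(N(C)S(C)(=O)=O)c4C3)n2)cc1C(F)(F)F` — in an assay on Sf9 cells for inhibition of tyrosine-protein kinase receptor UFO (Homo sapiens), read by luminescence and ADP-Glo (a higher number here means a weaker inhibitor, a lower number a stronger inhibitor), compound 1 gives > 20000 nM, a limit of the assay.
compound 2 `COc1ccc(C(F)(F)F)cc1Nc1ncc(C(F)(F)F)c(N2Cc3cccc(N(C)S(C)(=O)=O)c3C2)n1` — in this assay compound 2 gives > 20000 nM, likewise a limit.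
compound 3 `Cc1ccc(Nc2ncc(C(F)(F)F)c(N3Cc4cccc(N(C)S(C)(=O)=O)c4C3)n2)c(Cl)c1` — in this assay compound 3 gives > 20000 nM, again a limit.

All three values sit at the same limit (the limit of > 20000 nM in this assay, at which 3 of the 3 values shown sit), so none of the three compounds can be placed in order against the others, and compound 3 stands simply at that limit. The three measured steps, a step that the two limits leave unreadable from compound 1 to compound 2, a step that the two limits leave unreadable from compound 1 to compound 3 and a step that the two limits leave unreadable from compound 2 to compound 3, are therefore unreadable in size: changing the aryl group on the anilino nitrogen three ways has not produced a numerical inhibitory concentration in any case.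

Compound 4 `COc1cc(Nc2ncc(C(F)(F)F)c(N3Cc4cccc(N(C)S(C)(=O)=O)c4C3)n2)c(OC)cc1Cl` continues this variation: 4-chloro-2,5-dimethoxyphenyl in place of 2-chloro-4-methylphenyl on a nitrogen on an aromatic ring. Every measured step that bears on it, each exchange of one aryl group for another at this nitrogen, left the value at the limit, so the step expected in this assay is again one that cannot be read rather than a measurable gain. For compound 4 the estimate is therefore 30000 nM, with a range from 10000 nM to 100000 nM, which as a step means an expected step that the limit leaves unreadable from compound 3 to compound 4, most probably reported once more as a limit.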

Compound 4, half-maximal inhibitory concentration: > 20000 nM
Compound 4 ended at the assay's limit; the forecaster's own chance of this, stated with the estimate: 85%; the middle value lies beyond the limit too.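

In this assay compound 4 gives > 20000 nM as a limit and not as a number. For the compounds shown here, no step among compound 1, compound 2, compound 3 and compound 4 can be read, since all four values stand at one limit: the limit of > 20000 nM in this assay, at which 4 of the 4 values shown sit. The compounds shown leave open whether any aryl group on this nitrogen of the shared core gives a measurable inhibitory concentration, and how these four compounds rank.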